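The source may report more compounds than this note shows. Statements on the series, on what has been measured and on what is new or still open speak of the compounds shown alone.

Compound 1, with structure `COc1ccc(F)cc1N1C(=O)CSC1c1cccc(C(=O)NCCCCc2ccccc2)c1`, was tested in a functional assay on HOS-TE85 cells (Homo sapiens) for inhibition, read by CCK-8 assay, with a stated time of 72 h, tested at 1 uM (on this read-out higher numbers stand for more inhibition at the one concentration tested (going by the name of the read-out) and lower numbers for less inhibition), where compound 1 gives 95%. Among the measured compounds shown here, compound 2, with structure `O=C(NCCCCc1ccccc1)c1cccc(C2SCC(=O)N2c2cccc(F)c2)c1`, is the only other compound measured, and in this assay compound 2 gives 94%. For the measured compounds named here, the single measured step, a number 1 percentage points lower from compound 1 to compound 2 (within the scatter), shows that removing a methoxy group from the aromatic ring on the ring nitrogen left the inhibition essentially unchanged, so compound 1 and compound 2 stand within the scatter of each other.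

Compound 3, with structure `COc1cccc(OC)c1N1C(=O)CSC1c1cccc(C(=O)NCCCCc2ccccc2)c1`, differs from compound 1 by 2,6-dimethoxyphenyl in place of 5-fluoro-2-methoxyphenyl on an amide-type nitrogen in a ring. Going by the values given here, no measured step covers this exact exchange; the one step at that ring, a number 1 percentage points lower from compound 1 to compound 2 (within the scatter), was within the scatter. Compound 3 is therefore expected to show at most a small step, a number 5 percentage points lower from compound 1 to compound 3 (within the scatter), in this assay. Compound 3 is estimated to give 90%, with a range from 70% to 98%.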

Compound 3, a percentage reported as inhibition, at one concentration (the size of the read-out at that concentration, not a potency): 95%
Beside the measured number, compound 3's estimate is 5 percentage points below it; measured number inside the range.
By their numbers in this assay, from the lowest: compounds 2, 1 and 3 (each within the scatter of the next).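

In this assay, the position on the amide-type nitrogen now carries a group with two methoxy groups and no fluorine. Replacing 5-fluoro-2-methoxyphenyl with 2,6-dimethoxyphenyl gives no change at the digits printed from compound 1 to compound 3 (within the scatter), and replacing 3-fluorophenyl with the same group gives a number 1 percentage points higher from compound 2 to compound 3 (within the scatter), so this position accepts all three aromatic groups, and the three compounds stand within the scatter of one another at the single concentration tested. No available evidence explains why these groups give such similar readings.

Still open, as far as these compounds go, is whether the reading would hold with an amine or a carboxylic acid on this phenyl ring, or with a butyl chain in place of the ring. From the compounds shown here alone, a single concentration gives no potency, so it also remains unknown whether these three compounds would separate at lower concentrations.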